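A few compounds are considered here, and "the series" means these few. Any claim that something is new, unique, unknown or untested is made for them only; others in the source may bear on it.

Of the compounds shown here, two have so far been tested in an assay for inhibition of LL-diaminopimelate aminotransferase, chloroplastic (Arabidopsis thaliana), tested at 10 uM; on this read-out lower numbers stand for less inhibition and higher numbers for more inhibition at the one concentration tested (going by the name of the read-out). Compound 1 `COc1cc(-c2nnc(SCC(=O)c3ccc(F)cc3)n2-c2ccccc2)cc(OC)c1OC` gives 14% in this assay. Compound 2 `CCOC(=O)C1=C(Nc2ccc(OC)cc2)S/C(=C\c2ccc(N(C)C)cc2)C1=O` gives 22% in this assay. Compound 2 stands at the top of these two numbers, yet its gap to compound 1 lies within the usual scatter of such readings, so the two numbers are best read as level on this evidence.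

Compound 3 `CCOC(=O)C1=C(Nc2ccc([N+](=O)[O-])cc2)S/C(=C\c2ccc(N(C)C)cc2)C1=O` has not yet been measured. It differs from compound 2 in a single place: nitro in place of methoxy on an aromatic carbon. Among the measured compounds shown here, no pair of measured compounds shows what this kind of exchange does in this assay, so the expectation rests only on the two readings at hand and on the fact that the rest of the molecule is unchanged. Compound 3 is expected to land close to compound 2, with the step of a number 2 percentage points lower from compound 2 to compound 3 (within the scatter) staying within the scatter rather than moving clearly up or down. For compound 3 a reading of 20% is estimated, with a likely range from 8% to 32%.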

Compound 3, a percentage reported as inhibition, at one concentration (the size of the read-out at that concentration, not a potency): 19%
Compound 3: the middle estimate sits 1 percentage points above what was measured; measured number inside the range.
By their numbers in this assay, from the lowest: compounds 1, 3 and 2 (each within the scatter of the next).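

Among the compounds shown here, compound 2 and compound 3 are the first pair here that differ in only one place, so this is the first direct look at what a change on this aromatic carbon, para to a large group, does in this assay. Putting nitro in place of methoxy, which turns the (4-methoxyphenyl)amino group into (4-nitrophenyl)amino, gives a number 3 percentage points lower from compound 2 to compound 3 (within the scatter), so this reading does not tell the two compounds apart, and the rest of the molecule is the same in both. Nothing measured here offers an explanation for this result, and this single pair shows only what this one exchange does on this one core.

Open, from the compounds shown here alone, is whether an amine or a carboxylic acid on the same aromatic carbon would also read level with compound 2, or whether a different group there would give a step beyond the scatter. Also open is what a change elsewhere on the shared core would do, such as a carboxylic acid in place of the ethyl ester, since every reading shown comes from a single concentration.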